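Lengthening the Amide Side Chain Toward a Fourth Compound

This account rests on a few compounds, and the source may have more. Where it says the series, first, only, none or still open, it means among the compounds named here.

Compound 1 `CC(C)C(=O)Nc1c(C(O)(C(F)(F)F)C(F)(F)F)ccc2ccccc12`: 6630 nM in an assay on LtK cells with ATP-sensitive inward rectifier potassium channel 11 (Homo sapiens) as the target; a higher number here means that more compound is needed for the effect, a lower number that less compound is needed
Compound 2 `O=C(Nc1c(C(O)(C(F)(F)F)C(F)(F)F)ccc2ccccc12)C1CCCC1`: 495 nM in this assay
Compound 3 `O=C(CC1CCCC1)Nc1c(C(O)(C(F)(F)F)C(F)(F)F)ccc2ccccc12`: 81 nM in this assay

Compound 3 stands lowest of the three numbers in this assay. Both a 6.1-fold lower number from compound 2 to compound 3 (0.79 log units; beyond the scatter) and an 82-fold lower number from compound 1 to compound 3 (1.91 log units; beyond the scatter) lie beyond the scatter, so compound 3 is the most potent of the three measured here.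

Compound 4 `O=C(Nc1ccc(Cl)cc1)Nc1c(C(O)(C(F)(F)F)C(F)(F)F)ccc2ccccc12` has not yet been measured. It differs from compound 3 in one place: (4-chlorophenyl)amino in place of cyclopentylmethyl on a carbonyl carbon.

Among the measured compounds shown here, three measured steps bear on this change, all at the same carbonyl carbon: a 13-fold lower number from compound 1 to compound 2 (1.13 log units; beyond the scatter), an 82-fold lower number from compound 1 to compound 3 (1.91 log units; beyond the scatter) and a 6.1-fold lower number from compound 2 to compound 3 (0.79 log units; beyond the scatter). In each case a larger, more extended group in that place gave a lower number. For the measured compounds named here, the group entering in compound 4 is larger still, but it brings an aromatic ring and a hydrogen-bond donor where compound 3 carries a non-aromatic ring with neither, and no measured compound has such a group, so the size of the step is uncertain.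

A modest step to a lower number is expected, a 1.2-fold higher number from compound 3 to compound 4 (0.09 log units; within the scatter). Compound 4 is therefore estimated at 100 nM in this assay, with a range from 20 nM to 600 nM.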

Compound 4, half-maximal effective concentration: 276 nM
Compound 4: the middle estimate sits 2.8-fold (0.44 log units) below what was measured; the range from low to high includes it.
By their numbers in this assay, from the lowest: compound 3; then compounds 4 and 2 (each within the scatter of the next); then compound 1.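

Compound 4 breaks the run seen in this assay, where each larger group at this carbonyl carbon had given a lower number: (4-chlorophenyl)amino has more heavy atoms than cyclopentylmethyl, yet the change gives a 3.4-fold higher number from compound 3 to compound 4 (0.53 log units; beyond the scatter). Among these four compounds, then, size alone does not set the number, and compound 4 is the one that goes against the earlier pattern, although the place still accepts an aromatic ring and a hydrogen-bond donor, with a 24-fold lower number from compound 1 to compound 4 (1.38 log units; beyond the scatter) and, within the scatter, a 1.8-fold lower number from compound 2 to compound 4 (0.25 log units; within the scatter), so compound 2 and compound 4 cannot be told apart here. No measurement is available that would explain the rise from compound 3 to compound 4.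

This single change swaps the non-aromatic ring for an aromatic one, adds a nitrogen with its hydrogen and adds a chlorine, so the compounds shown do not reveal which of these parts matters. On these data alone, how a cyclopentylamino group, which keeps the five-membered ring and adds the nitrogen, or a phenylamino group without the chlorine would compare remains open.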